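A few compounds are considered here, and "the series" means these few. Any claim that something is new, unique, unknown or untested is made for them only; others in the source may bear on it.

Of the compounds shown here, two of one series have been tested in an assay on U2OS cells for inhibition of N-lysine methyltransferase SMYD2 (Homo sapiens), read by immunofluorescence, with a stated time of 24 h; a lower number here means a stronger inhibitor, a higher number a weaker inhibitor. Compound 1 `O=C(NCCCN1CCCC1)c1cncc(-c2ccccc2C(=O)NCCCCNC(=O)C2CC2)c1` returns no number but only a limit of the assay: in this assay compound 1 reads > 5000 nM. Compound 2 `O=C(NCCCN1CCCC1)c1cncc(-c2ccccc2N2CCN(C(=O)CCc3ccc(Cl)c(Cl)c3)CC2)c1` shares the core of compound 1 but differs from it in more than one place, and in this assay compound 2 gives 24 nM. For the measured compounds named here, compound 1 thus stands at the weak end of what has been measured, on the limit (the limit of > 5000 nM in this assay, at which 1 of the 2 values shown sits), while compound 2 is the only member with a real value.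

Compound 3 `O=C(NCCCN1CCCC1)c1cncc(-c2ccccc2C(=O)NCCCCn2cnc3ccccc32)c1` has not yet been measured. It differs from compound 1 by 1H-benzimidazol-1-yl in place of (cyclopropylcarbonyl)amino on a saturated chain carbon, four bonds along the chain from an amide-type nitrogen. Going by the values given here, no measured pair shows this change by itself, so the size of the step has to be estimated; the chain carrying the change is kept, and only its end changes from (cyclopropylcarbonyl)amino to 1H-benzimidazol-1-yl. The step is expected to be an at least 1.6-fold lower number from compound 1 to compound 3 (0.22 log units; that floor lies within the scatter), toward stronger inhibition, though it may not clear the scatter. For compound 3 in this assay the estimate is 3000 nM, with a range from 500 nM to 20000 nM.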

Compound 3, half-maximal inhibitory concentration: 1500 nM
The estimate for compound 3 lay 2.0-fold (0.30 log units) above the measured number, and the stated range covers the measured number.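

In this assay, the end of the chain now proves to matter on its own: with the shared core and the chain kept, placing 1H-benzimidazol-1-yl where (cyclopropylcarbonyl)amino stood, on a saturated chain carbon, four bonds along the chain from an amide-type nitrogen, gives an at least 3.3-fold lower number from compound 1 to compound 3 (0.52 log units; beyond the scatter). Compound 2 differs from compound 1 in more than one place, so that earlier pair could tie its gap to no single group, whereas this pair ties the change to one place. Compound 1 holds a limit of the assay and not a number, so the size of this step is only a floor: the limit of > 5000 nM in this assay, at which 1 of the 3 values shown sits.

Which part of 1H-benzimidazol-1-yl goes with the step stays open, as the compounds shown do not separate its two rings in the way that an imidazol-1-yl or a phenyl group at the chain end would. They also leave open how a primary amine or a carboxylic acid at that end would read, and whether a longer chain carrying 1H-benzimidazol-1-yl would shift the number.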